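Chain changes at the ring nitrogen of a trimethoxybenzyl purine series

The compounds below may be only part of what the source reports. "The series", "measured", "known", "first", "only" and "open" are said of these compounds alone.

Measured so far:
- compound 1 `C=CCCCn1c(Cc2cc(OC)c(OC)c(OC)c2)nc2c(N)nc(F)nc21`: 44700 nM
- compound 2 `COc1cc(Cc2nc3c(N)nc(F)nc3n2CC2CCCO2)cc(OC)c1OC`: 22900 nM
- compound 3 `CC#CCCn1c(Cc2cc(OC)c(OC)c(OC)c2)nc2c(N)nc(F)nc21`: 37200 nM

All three compounds share one core and differ only in the chain on the aromatic nitrogen. In a functional assay on MCF7 cells (Homo sapiens) for antiproliferative activity (on this read-out higher numbers stand for weaker inhibition and lower numbers for stronger inhibition), compound 3 gives 37200 nM, the second highest of the three numbers; its nearest neighbour is compound 1 and its furthest is compound 2, and every step among them lies within the scatter: a 2.0-fold lower number from compound 1 to compound 2 (0.29 log units; within the scatter), a 1.2-fold lower number from compound 1 to compound 3 (0.08 log units; within the scatter), a 1.6-fold higher number from compound 2 to compound 3 (0.21 log units; within the scatter).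

Compound 4 `CCCCn1c(Cc2cc(OC)c(OC)c(OC)c2)nc2c(N)nc(F)nc21` carries a butyl chain instead. The change is ethyl in place of prop-1-yn-1-yl on a saturated chain carbon, two bonds along the chain from an aromatic nitrogen. The step that bears on it most directly is a 1.2-fold lower number from compound 1 to compound 3 (0.08 log units; within the scatter), where allyl and prop-1-yn-1-yl at this same position gave numbers within the scatter of each other; the other two chain changes also stayed within the scatter. On that basis no step beyond the scatter is expected from compound 3 to compound 4 in this assay, in either direction, and the expected change is a 1.1-fold higher number from compound 3 to compound 4 (0.03 log units; within the scatter).

Compound 4 is therefore estimated at 40000 nM, with a likely range from 18000 nM to 90000 nM.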

Compound 4, half-maximal inhibitory concentration: 24000 nM
Estimate against measurement, compound 4: 1.7-fold (0.22 log units) above; the measured number falls inside the stated range.
By their numbers in this assay, from the lowest: compounds 2, 4, 3 and 1 (each within the scatter of the next).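

In this assay, for the compounds shown here, the fully saturated butyl chain of compound 4 gives the first direct reading of what happens when the triple bond is lost at this position, and the step stays within the scatter: a 1.6-fold lower number from compound 3 to compound 4 (0.19 log units; within the scatter). The other two comparisons agree, with propyl in place of oxolan-2-yl giving a 1.0-fold higher number from compound 2 to compound 4 (0.02 log units; within the scatter) and methyl in place of vinyl giving a 1.9-fold lower number from compound 1 to compound 4 (0.27 log units; within the scatter), so neither the triple bond, the double bond nor the oxolane ring separates these compounds from a plain butyl chain. No measurement shown here explains why the four chains give numbers so close to one another.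

It remains open whether any group on this chain can move the number beyond the scatter, since the four chains shown do not include an amine, a carboxylic acid or a longer chain such as octyl. The compounds also leave open whether this flat result would hold if the fluorine or the methoxy groups on the shared core were replaced, as all four carry them unchanged.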